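This account rests on a few compounds, and the source may have more. Where it says the series, first, only, none or still open, it means among the compounds named here.

Measured so far in a functional assay on HT-29 cells (Homo sapiens) for antiproliferative activity, read by sulforhodamine B assay, with a stated time of 72 h; a higher number here means a weaker inhibitor, a lower number a stronger inhibitor:
compound 1, `COc1cccc(NC(=S)N/N=C/c2ccc3ccccc3n2)c1`: 82400 nM
compound 2, `Cc1ccc(NC(=O)N/N=C/c2ccc3ccccc3n2)cc1`: > 100000 nM
compound 3, `NC(=S)N/N=C/c1nc2ccccc2s1`: > 100000 nM

Going by the values given here, compound 1 `COc1cccc(NC(=S)N/N=C/c2ccc3ccccc3n2)c1` is the only compound that returns a number in this assay, where compound 1 gives 82400 nM. Compound 2 `Cc1ccc(NC(=O)N/N=C/c2ccc3ccccc3n2)cc1` reaches only a limit of the assay in this assay, at > 100000 nM. Compound 3 `NC(=S)N/N=C/c1nc2ccccc2s1` likewise returns a limit in this assay, at > 100000 nM. Compound 1 therefore stands alone with a finite value, while the two others sit at the limit of > 100000 nM in this assay, at which 2 of the 3 values shown sit. Among the compounds with values here, no pair of measured compounds differs in a single place, so no measured step gives a size for a change of the kind considered here.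

Compound 4 `S=C(N/N=C/c1ccc2ccccc2n1)Nc1ccccc1` is to be measured in this assay. It differs from compound 1 by hydrogen in place of methoxy on an aromatic carbon; the methoxy leaves and a hydrogen enters, on an aromatic carbon of a six-membered aromatic ring of carbon only, so that the 3-methoxyphenyl becomes a phenyl. With compound 1 itself weak in this assay at 82400 nM, the step from compound 1 to compound 4 is expected to be small, a 1.2-fold higher number from compound 1 to compound 4 (0.06 log units; within the scatter), not beyond the usual scatter. Compound 4 is estimated at 95000 nM, within 40000 nM to 220000 nM.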

Compound 4, half-maximal inhibitory concentration: 17000 nM
Estimate against measurement, compound 4: 5.6-fold (0.75 log units) above, and the stated range ends above it.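

In this assay, going by these compounds alone, the aromatic carbon carrying the methoxy is the first place where a single change can be read: hydrogen in place of methoxy gives a 4.8-fold lower number from compound 1 to compound 4 (0.69 log units; beyond the scatter) and this modest step lies beyond the scatter. The place therefore responds to what it carries, and the methoxy is not needed for a finite value on this core, as the plain phenyl of compound 4 also gives one. The change rests on this one pair, and the other compounds offer no second reading of it, as their entries are limits of the assay and not numbers: the limit of > 100000 nM in this assay, at which 2 of the 4 values shown sit.

Still open, from the compounds shown here alone, is whether the lower number belongs to the loss of the methoxy in particular or to the loss of any group on this carbon, which a hydroxyl, a chlorine, an amine or a carboxylic acid in the same place would help to separate. Also open, going by these compounds, is whether a longer chain such as ethoxy, or a methoxy on another carbon of the ring, would give a step of similar size.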